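The source may report more compounds than this note shows. Statements on the series, on what has been measured and on what is new or still open speak of the compounds shown alone.

Measured compounds:
compound 1, `CNC(=O)N1CCCc2ccc(NC(=O)c3ccc(-c4ccccc4)cc3)cc21`: 74.3%
compound 2, `CNC(=O)N1CCCc2ccc(NC(=O)c3ccccc3-c3ccccc3)cc21`: 60.4%
compound 3, `CNC(=O)N1CCCc2ccc(NC(=O)c3cccc(-c4ccn(C)n4)c3)cc21`: 99.5%

All three were tested in a functional assay on MV4-11 cells (Homo sapiens) for antiproliferative activity, with a stated time of 6 days, tested at 6.25 uM; on this read-out lower numbers stand for a weaker effect and higher numbers for a stronger effect at the one concentration tested. Compound 1 gives 74.3% and stands second highest of the three numbers. Compound 2 gives 60.4%, a lower number and a gap beyond the usual scatter, while compound 3 gives 99.5%, a higher number and also a gap beyond the scatter.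

Compound 4, `CNC(=O)N1CCCc2ccc(NC(=O)c3ccc(-c4ccccn4)cc3)cc21`, has not yet been measured. It differs from compound 1 in a single place: pyridin-2-yl in place of phenyl on an aromatic carbon. The change sits on an aromatic carbon of a six-membered aromatic ring of carbon only. Going by the values given here, no measured pair in this set shows this exact change, so its effect cannot be read off from the data and the expectation rests on the closeness of the two groups as counted. The step of a number 3.7 percentage points higher from compound 1 to compound 4 (within the scatter) is expected to stay within the scatter, with at most a slight upward lean. Compound 4 is therefore estimated at 78%, with a range from 58% to 95%.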

Compound 4, a percentage reported as inhibition, at one concentration (the size of the read-out at that concentration, not a potency): 79.2%
The estimate for compound 4 lay 1.2 percentage points below the measured number; the measured number falls inside the stated range.
By their numbers in this assay, from the lowest: compound 2; then compounds 1 and 4 (each within the scatter of the next); then compound 3.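

In this assay, pyridin-2-yl in place of phenyl gives a number 4.9 percentage points higher from compound 1 to compound 4 (within the scatter), so this swap on an aromatic carbon, para to a large group, leaves the read-out within the usual scatter. Going by these compounds alone, this is the first direct reading of a single change in the set, and it shows that this position accepts a ring nitrogen, with its one added hydrogen-bond acceptor, without a clear shift at the one concentration tested. Nothing measured here bears on why the read-out stays within the scatter.

Still open, on these data alone, is whether a carboxylic acid or a piperidine at this same place would give a similar number. Also open, as far as these compounds go, is whether pyridin-3-yl, with the ring nitrogen elsewhere, would behave like pyridin-2-yl, and a single concentration cannot rank potency.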